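Chloro in Place of Hydroxy on the Shared Core

The compounds below may be only part of what the source reports. "The series", "measured", "known", "first", "only" and "open" are said of these compounds alone.

Compound 1 `COc1ccc2[nH]c(C(=O)NCCCN3CCN(c4ccccc4OC)CC3)cc2c1`: 1450 nM
Compound 2 `COc1ccccc1N1CCN(CCCNC(=O)c2cc3cc(O)ccc3[nH]2)CC1`: 155 nM
Compound 3 `COc1ccccc1N1CCN(CCCNC(=O)c2cc3cccc([N+](=O)[O-])c3[nH]2)CC1`: 646 nM

Of the compounds shown here, three share one core and have been tested in an assay on isolated protein (spleen, strain Sprague-Dawley) for antagonist activity at Alpha-1B adrenergic receptor (Rattus norvegicus), with a stated time of 20 min; a lower number here means tighter binding, a higher number weaker binding. Compound 2 gives 155 nM, the lowest number of the three, with compound 3 giving 646 nM and compound 1 giving 1450 nM. Compound 4 `COc1ccccc1N1CCN(CCCNC(=O)c2cc3cc(Cl)ccc3[nH]2)CC1` has not yet been measured. It differs from compound 2 by chloro in place of hydroxy on an aromatic carbon. Going by the values given here, no measured step makes this exact change, but one step touches the same hydroxy group: a 9.4-fold lower number from compound 1 to compound 2 (0.97 log units; beyond the scatter). That step shows that replacing the hydroxy's hydrogen with methyl costs a good deal of binding, so the hydroxy seems to matter here; removing it entirely in favor of chloro may cost something too. Compound 4 is therefore expected to show a higher number than compound 2, with a 3.9-fold higher number from compound 2 to compound 4 (0.59 log units; beyond the scatter). The estimate for compound 4 is 600 nM, within a range from 200 nM to 1800 nM.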

Compound 4, dissociation constant: 257 nM
Compound 4: the middle estimate sits 2.3-fold (0.37 log units) above what was measured, within the range that was stated.
By their numbers in this assay, from the lowest: compounds 2 and 4 (each within the scatter of the next); then compound 3; then compound 1.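

In this assay, replacing the hydroxy with chloro gives a 1.7-fold higher number from compound 2 to compound 4 (0.22 log units; within the scatter) and so does not separate the two groups, even though chloro is counted with no hydrogen-bond donor or acceptor. Methoxy at the same position does stand apart: chloro in its place gives a 5.6-fold lower number from compound 1 to compound 4 (0.75 log units; beyond the scatter) and the change is beyond the scatter. Compound 4 lacks the hydroxy hydrogen just as compound 1 does, so the weak binding of compound 1 goes with the methoxy and not simply with losing that hydrogen, though no measurement here explains this.

As far as these compounds go, only hydroxy, chloro and methoxy are compared at this position, so how much variety it accepts remains open. An amine, a carboxylic acid or a longer ethoxy chain could show whether methoxy marks the start of a wider limit.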